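This account rests on a few compounds, and the source may have more. Where it says the series, first, only, none or still open, it means among the compounds named here.

Three compounds share one core, and only the aryl ether end changes between them. Compound 1 `c1ccc(OCC2[C@H]3CN(Cc4cn5ccccc5n4)C[C@@H]23)cc1` has no result in an in vitro ADME assay on microsomes from liver (Homo sapiens) for metabolic stability, tested at 1 uM (on this read-out lower numbers stand for slow clearance and higher numbers for fast clearance), where compound 1 stands as "not determined" (no result reported). Going by the values given here, compound 2 `CC(C)c1ccc(OCC2[C@H]3CN(Cc4nc5ccccc5n4C)C[C@@H]23)cc1` gives 5.8 mL/min/kg in this assay, the only plain number among the three entries. For compound 3 `Cn1c(CN2C[C@@H]3C(COc4ccc(C(F)(F)F)cc4)[C@@H]3C2)nc2ccccc21` the result in this assay is a limit, < 5.3 mL/min/kg. The step of an at least 1.0-fold lower number from compound 2 to compound 3 (0.03 log units; that floor lies within the scatter) can be sized only to its floor, which is the limit of < 5.3 mL/min/kg in this assay, at which 1 of the 3 values shown sits. Compound 4 `Cn1c(CN2C[C@@H]3C(COc4ccc(Cl)cn4)[C@@H]3C2)nc2ccccc21` differs from compound 2 by 5-chloropyridin-2-yl in place of 4-isopropylphenyl on an oxygen on a saturated carbon. Among the compounds with values here, the single measured step at this position, from compound 2 to compound 3, stays within the scatter, and the exchange leading to compound 4 has no direct precedent among the measured compounds, so no move beyond the scatter is expected, with a fair chance that this assay again returns only a limit. Compound 4 is estimated at 5.5 mL/min/kg, in a range from 3 mL/min/kg to 11 mL/min/kg. The expected step is a 1.1-fold lower number from compound 2 to compound 4 (0.02 log units; within the scatter).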

Compound 4, clearance: 12.3 mL/min/kg
Beside the measured number, compound 4's estimate is 2.2-fold (0.35 log units) below it; the whole stated range lies below it.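

In this assay, the exchange of 4-isopropylphenyl for 5-chloropyridin-2-yl gives a 2.1-fold higher number from compound 2 to compound 4 (0.33 log units; beyond the scatter), which shows that a change at this place, on the oxygen on a saturated carbon, can move the read-out beyond the scatter, something the earlier step, an at least 1.0-fold lower number from compound 2 to compound 3 (0.03 log units; that floor lies within the scatter), could not show. Compound 3 still stands only as a limit: the limit of < 5.3 mL/min/kg in this assay, at which 1 of the 4 values shown sits. Nothing shown here accounts for the rise seen with compound 4.

The exchange brings in the ring nitrogen and the chlorine together, so the compounds shown leave open which of the two carries the step, as they include neither a phenyl ring with chlorine nor a pyridine ring without it. They also leave open how a nitrile or a methoxy group on this ring would read in this assay.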